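A few compounds are considered here, and "the series" means these few. Any claim that something is new, unique, unknown or untested is made for them only; others in the source may bear on it.

Measured compounds:
- compound 1, `CCCc1nc(-c2ccccc2)c(CNCCCN2CCN(c3cccc(F)c3)CC2)o1`, 68.9%
- compound 2, `Cc1nc(-c2ccccc2)c(CNCCCN2CCN(c3ccc(Cl)cc3)CC2)o1`, 38.1%
- compound 3, `CCCc1nc(-c2ccccc2)c(CNCCN2CCN(C(c3ccccc3)c3ccccc3)CC2)o1`, 71.9%

These three compounds were tested in an assay on HEK293 cells for inhibition of Voltage-dependent T-type calcium channel subunit alpha-1G (Homo sapiens), read by fluorescence, tested at 10 uM; a lower number here means less inhibition, a higher number more inhibition at the concentration tested (going by the name of the read-out). Compound 1 gives 68.9% in this assay, which is the second highest of the three numbers. Compound 3 gives 71.9%, a number close to that of compound 1 and within the usual scatter, so the two cannot be told apart. Compound 2 gives 38.1%, a number well below that of compound 1 and beyond the scatter; compound 2 differs from compound 1 in more than one place, so nothing is known about which of its changes matters.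

Compound 4, `CCCc1nc(-c2ccccc2)c(CNCCCN2CCN(c3cccc(C)c3)CC2)o1`, has not yet been measured. It differs from compound 1 in one place: methyl in place of fluoro on an aromatic carbon. Among the measured compounds shown here, no pair of measured compounds differs by only this kind of swap, so there is no measured step to lean on. Because compound 1 gives 68.9% and compound 3, with a larger change at the same end of the molecule, gives 71.9%, a step of about the size of the scatter is expected, in no particular direction. Compound 4 is therefore expected to give 65%, with a range from 45% to 85%, meaning an expected step of a number 3.9 percentage points lower from compound 1 to compound 4 (within the scatter).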

Compound 4, a percentage reported as inhibition, at one concentration (the size of the read-out at that concentration, not a potency): 47.8%
The estimate for compound 4 lay 17.2 percentage points above the measured number; low and high end bracket the measured number.
By their numbers in this assay, from the lowest: compounds 2 and 4 (each within the scatter of the next); then compounds 1 and 3 (each within the scatter of the next).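

In this assay, among the compounds shown here, the change from 3-fluorophenyl to 3-methylphenyl gives a number 21.1 percentage points lower from compound 1 to compound 4 (beyond the scatter) and is the only step here that isolates a single place in the molecule. This place on the aromatic ring therefore matters: exchanging one heavy atom for one other heavy atom, with no ring, hydrogen-bond donor, hydrogen-bond acceptor or net charge entering or leaving, is enough to move the number beyond the scatter. No measurement available here explains why the methyl compound gives the lower number.

The compounds shown do not tell whether other groups at this place, such as methoxy, nitrile or trifluoromethyl, would stay close to fluoro or fall with methyl. As far as these compounds go, it also remains open whether the same swap would give a step of this size on a different core.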